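Aryl swap on saturated ring carbon: thiourea analogue

The source may hold more compounds than are shown below. What is called first, only, known or untested is meant among the compounds shown, and "the series" means these compounds.

Measured so far in a functional assay on HCT-116 cells (Homo sapiens) for cytotoxicity, read by MTT assay, with a stated time of 48 h; a higher number here means a weaker inhibitor, a lower number a stronger inhibitor:
compound 1 `COc1cc(/C=C/C(=O)C2=C(/C=C/c3ccc(O)c(OC)c3)NC(=O)NC2c2ccc(C)cc2)ccc1O` gives 12500 nM
compound 2 `COc1cc(/C=C/C(=O)C2=C(/C=C/c3ccc(O)c(OC)c3)NC(=O)NC2c2ccccc2O)ccc1O` gives 100000 nM
compound 3 `COc1cc(/C=C/C(=O)C2=C(/C=C/c3ccc(O)c(OC)c3)NC(=S)NC2c2ccc(C)cc2)ccc1O` gives 50000 nM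

The change 2-hydroxyphenyl in place of 4-methylphenyl on a saturated ring carbon produced an 8.0-fold higher number from compound 1 to compound 2 (0.90 log units; beyond the scatter). Compound 3 differs from compound 1 in more than one place; the difference between the two cores is not broken down here. Compound 3 and compound 2 lie within the scatter of each other, while compound 3 stands beyond the scatter from compound 1.

Compound 4 `COc1cc(/C=C/C(=O)C2=C(/C=C/c3ccc(O)c(OC)c3)NC(=S)NC2c2ccccc2O)ccc1O` is not yet measured. It carries the same change relative to compound 3, (2-hydroxyphenyl in place of 4-methylphenyl on a saturated ring carbon), at the same place as before. Among the compounds with values here, for compound 4 a step of a 4.0-fold higher number from compound 3 to compound 4 (0.60 log units; beyond the scatter) is expected in this assay, set beside the earlier one, because an 8.0-fold higher number from compound 1 to compound 2 (0.90 log units; beyond the scatter) is the only precedent and rests on a single pair. Since compound 3 already starts weak, the estimated value may lie where the assay reports only a limit. Compound 4 is estimated at about 200000 nM, with the range 60000 nM to 600000 nM.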

Compound 4, half-maximal inhibitory concentration: 100000 nM
Beside the measured number, compound 4's estimate is 2.0-fold (0.30 log units) above it; the range from low to high includes it.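

In this assay, 2-hydroxyphenyl in place of 4-methylphenyl on a saturated ring carbon gives a 2.0-fold higher number from compound 3 to compound 4 (0.30 log units; within the scatter), so the step seen on the core of compound 1 does not carry over at the same size to the core of compound 3: the same change on two cores in this assay, an 8.0-fold higher number (0.90 log units; beyond the scatter) from compound 1 to compound 2 and a 2.0-fold higher number (0.30 log units; within the scatter) from compound 3 to compound 4, 4.0-fold (0.60 log units) apart, beyond the scatter of two such steps

On the core of compound 3 the step lies within the scatter, so no effect of the change is established there. Two pairs do not show why the steps differ, nor whether the gap would hold on any other core.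

The compounds shown leave open how an aryl group carrying an amine or a carboxylic acid, in place of 4-methylphenyl, would read in this assay on either core.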